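The source may report more compounds than this note shows. Statements on the series, on what has been measured and on what is new or still open speak of the compounds shown alone.

Measured compounds:
compound 1 `CCSC(=O)C1=C(C)NC(=O)NC1c1ccsc1` gives 11% in an assay on membranes from CHO cells for displacement of a labelled ligand from adenosine receptor A1 (Homo sapiens), read by scintillation counting, with a stated time of 60 min, tested at 1 uM; on this read-out higher numbers stand for more inhibition at the one concentration tested (going by the name of the read-out) and lower numbers for less inhibition.
compound 2 `CCC(C)OC(=O)C1=C(C)NC(=O)NC1c1ccco1` gives 6% in this assay.

Both numbers are small. Compound 2 has the lower of the two, and its nearest neighbour is compound 1, whose number is higher by an amount that lies within the scatter of repeated measurements, so no order between them can be claimed.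

Compound 3 `CCC(C)OC(=O)C1=C(C)NC(=O)NC1c1ccsc1` has not yet been measured. It differs from compound 2 in one place: thiophen-3-yl in place of furan-2-yl on a saturated ring carbon. No measured pair shows what thiophen-3-yl in place of furan-2-yl does on this core, so the expectation rests only on the two numbers shown, which are low and close to each other. The step from compound 2 to compound 3 is expected to be small, a number 3 percentage points higher from compound 2 to compound 3 (within the scatter), not beyond the scatter in either direction. Compound 3 is therefore estimated at 9%, with a range from 0% to 20%.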

Compound 3, a percentage reported as inhibition, at one concentration (the size of the read-out at that concentration, not a potency): 5%
Estimate against measurement, compound 3: 4 percentage points above; the measured number falls inside the stated range.
By their numbers in this assay, from the lowest: compounds 3, 2 and 1 (each within the scatter of the next).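

Thiophen-3-yl in place of furan-2-yl on the saturated ring carbon gives the first step at this position in this assay, with a number 1 percentage points lower from compound 2 to compound 3 (within the scatter), so with sec-butoxy on the carbonyl carbon the two rings cannot be told apart. With thiophen-3-yl held in that position, sec-butoxy in place of ethylsulfanyl on a carbonyl carbon gives a number 6 percentage points lower from compound 1 to compound 3 (within the scatter), so neither change shows a readable effect on the number. No further measurement bears on this result.

Neither step shows whether the shared core can reach a clearly higher number in this assay. As far as these compounds go, it remains open whether a phenyl ring on the saturated ring carbon, or an amine or a longer alkyl chain on the carbonyl carbon, would give a step beyond the scatter.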